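The source may hold more compounds than are shown below. What is called first, only, known or untested is meant among the compounds shown, and "the series" means these compounds.

In an ADME assay on HepG2 cells (Homo sapiens) for cytotoxicity, read by CellTiter-Glo and resazurin assay, with a stated time of 72 h (a lower number here means that less compound is needed, a higher number that more compound is needed for the effect), three close relatives that share one core have been tested, and none of them gave a number. Compound 1 `CCOc1cccc(-c2ccc(C(=O)N(Cc3cccc(OCCCCCC(=O)O)c3)C(C)C)cc2)c1` carries a free acid at the end of its chain; in this assay compound 1 reaches only > 20800 nM, which is a limit of the assay and not a measured number. Compound 2 `CCOC(=O)CCCCCOc1cccc(CN(C(=O)c2ccc(-c3cccc(C(C)=O)c3)cc2)C(C)C)c1` carries the ethyl ester instead and a 3-acetylphenyl group; in this assay compound 2 also stops at > 26000 nM, again a limit. Compound 3 `CCOC(=O)CCCCCOc1cccc(CN(C(=O)c2ccc(-c3ccc(C(C)=O)s3)cc2)C(C)C)c1` puts a 5-acetylthiophen-2-yl group in that place; in this assay compound 3 likewise stops at > 26000 nM, a limit once more. Going by the values given here, the only step between measured compounds is a step that the two limits leave unreadable from compound 2 to compound 3; both of its ends are limits, so its size is unknown. Compound 3 therefore stands at a limit, as do the other two values shown, which the limit of > 20800 nM in this assay, at which 1 of the 3 values shown sits, and the limit of > 26000 nM in this assay, at which 2 of the 3 values shown sit, record.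

Compound 4 `CCOC(=O)CCCCCOc1cccc(CN(C(=O)c2ccc(-c3cccc(OCC)c3)cc2)C(C)C)c1` differs from compound 3 by 3-ethoxyphenyl in place of 5-acetylthiophen-2-yl on an aromatic carbon. Among the compounds with values here, no measured step bears on this exchange with a readable size, so no step beyond the scatter is expected in this assay, and the expected step that the limit leaves unreadable from compound 3 to compound 4 rests on that alone. Compound 4 is accordingly expected at 30000 nM, within 10000 nM to 100000 nM, most likely reported again as a limit.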

Compound 4, half-maximal effective concentration: > 22300 nM
Compound 4 gave a limit, no number (the forecaster's own chance of this, stated with the estimate: 85%); the middle value lies beyond the limit too.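

The steps linking compound 4 to compound 1, compound 2 and compound 3 in this assay cannot be read, as each has a limit at both ends. The compounds shown leave open at what concentration, if any, these four relatives would reach the half-maximal effect in this assay and how their differing groups would compare.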